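The source may report more compounds than this note shows. Statements on the series, on what has been measured and on what is new or still open speak of the compounds shown alone.

Going by the values given here, in an ADME assay on BJ cells (Homo sapiens) for cytotoxicity, with a stated time of 72 h (on this read-out higher numbers stand for an effect only at larger amounts of compound and lower numbers for an effect already at smaller amounts), compound 2 `Cc1nn(-c2ccccc2)c2nc(-c3ccc(C(C)C)cc3)c(C#N)c(-c3ccccc3O)c12` gives 22600 nM, the only actual number so far. Compound 1 `CCc1ccc(-c2nc3c(c(C)nn3-c3ccccc3)c(-c3ccccc3O)c2C#N)cc1` reads > 20000 nM, which is a limit of the assay. The next analogue, compound 3 `Cc1nn(-c2ccccc2)c2nc(-c3ccc(C(F)(F)F)cc3)c(C#N)c(-c3ccccc3O)c12`, differs from compound 2 at one place: trifluoromethyl in place of isopropyl on an aromatic carbon, para to a large group. Among the compounds with values here, only one measured step touches this group, a step that the limit leaves unreadable from compound 1 to compound 2, and it yields no usable size because of the limit of > 20000 nM in this assay, at which 1 of the 2 values shown sits. The series therefore offers no measured size for a change at this group, and nothing that points in either direction. Compound 2 at 22600 nM is the only anchor, so a reading for compound 3 close to it is expected. A limit reading for compound 3 in this assay would be no surprise. The expected move, a 1.1-fold lower number from compound 2 to compound 3 (0.05 log units; within the scatter), is estimated to stay within the usual scatter. Compound 3 is estimated at 20000 nM, with an expected range of 10000 nM to 40000 nM.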

Compound 3, half-maximal effective concentration: 22900 nM
Compound 3: the middle estimate sits 1.1-fold (0.06 log units) below what was measured; low and high end bracket the measured number.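

Going by these compounds alone, at this position, on an aromatic carbon para to a large group, this assay now gives a first readable step for trifluoromethyl in place of isopropyl, and it is a 1.0-fold higher number from compound 2 to compound 3 (0.01 log units; within the scatter). A carbon-only group and a fluorine-bearing group of similar heavy-atom size therefore cannot be told apart by this read-out, so the exchange of 4-isopropylphenyl for 4-(trifluoromethyl)phenyl has no measurable consequence here. The steps that start from compound 1 remain unreadable: the limit of > 20000 nM in this assay, at which 1 of the 3 values shown sits.

Open is whether any group at this place can move the number beyond the scatter, since a carboxylic acid, an amine or a longer chain there has no reading among the compounds shown. From the compounds shown here alone, the nitrile and the rest of the shared core are also the same across compound 1, compound 2 and compound 3, so the effect of exchanging the nitrile for an amide, for example, remains unknown.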